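Moving the methoxy and adding a methyl on the aryl group

The source may hold more compounds than are shown below. What is called first, only, known or untested is meant among the compounds shown, and "the series" means these compounds.

Measured compounds:
compound 1 `Cc1nn(-c2nc(-c3ccc(Cl)c(Cl)c3)c(SC(C)C)s2)c(C(=O)O)c1-c1ccc(Cl)cc1` — 2500 nM
compound 2 `Cc1cccc(-c2c(C)nn(-c3nc(-c4ccc(Cl)c(Cl)c4)c(SC(C)C)s3)c2C(=O)O)c1` — 17000 nM
compound 3 `COc1cccc(-c2c(C)nn(-c3nc(-c4ccc(Cl)c(Cl)c4)c(SC(C)C)s3)c2C(=O)O)c1` — 14000 nM

In a functional assay on BJAB cells (Homo sapiens) for antiproliferative activity, with a stated time of 4 days (a higher number here means that more compound is needed for the effect, a lower number that less compound is needed), compound 3 stands second highest of the three, with compound 2 nearest, a 1.2-fold lower number from compound 2 to compound 3 (0.08 log units; within the scatter); compound 1 is furthest, a 5.6-fold higher number from compound 1 to compound 3 (0.75 log units; beyond the scatter). Compound 4 `COc1ccc(C)cc1-c1c(C)nn(-c2nc(-c3ccc(Cl)c(Cl)c3)c(SC(C)C)s2)c1C(=O)O` changes the same position: 2-methoxy-5-methylphenyl in place of 3-methoxyphenyl on an aromatic carbon. For the measured compounds named here, the steps that bear on it all touch this aryl group: a 6.8-fold higher number from compound 1 to compound 2 (0.83 log units; beyond the scatter) and a 5.6-fold higher number from compound 1 to compound 3 (0.75 log units; beyond the scatter), while a 1.2-fold lower number from compound 2 to compound 3 (0.08 log units; within the scatter). Exchanging one small substituent on this ring for another left the number essentially unchanged, so compound 4, which keeps a methoxy and gains a methyl, is expected to show a 1.1-fold higher number from compound 3 to compound 4 (0.03 log units; within the scatter), no step beyond the scatter. Compound 4 is therefore estimated at 15000 nM, within 5000 nM to 45000 nM.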

Compound 4, half-maximal effective concentration: 9500 nM
Compound 4: the middle estimate sits 1.6-fold (0.20 log units) above what was measured, within the range that was stated.
By their numbers in this assay, from the lowest: compound 1; then compounds 4, 3 and 2 (each within the scatter of the next).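

In this assay, a second substituent on this aryl group makes no difference beyond the scatter: swapping 3-methoxyphenyl for 2-methoxy-5-methylphenyl gives a 1.5-fold lower number from compound 3 to compound 4 (0.17 log units; within the scatter), and methoxy in place of hydrogen on the ring of compound 2 gives a 1.8-fold lower number from compound 2 to compound 4 (0.25 log units; within the scatter). The 4-chlorophenyl group of compound 1 remains apart from this doubly substituted aryl group, with a 3.8-fold higher number from compound 1 to compound 4 (0.58 log units; beyond the scatter). Nothing available explains these differences. Going by these compounds, what an amine or a nitrile on this aryl group would give remains open.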